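The source may hold more compounds than are shown below. What is called first, only, known or untested is meant among the compounds shown, and "the series" means these compounds.

Measured compounds:
compound 1 `O=C(N/N=C/c1c(-c2cc3ccc(Br)cc3oc2=O)[nH]c2ccccc12)c1ccccc1Cl` — > 192000 nM
compound 2 `O=C(N/N=C/c1c(-c2cc3ccc(Br)cc3oc2=O)[nH]c2ccccc12)c1cccc(Br)c1` — > 200000 nM
compound 3 `O=C(N/N=C/c1c(-c2cc3ccc(Br)cc3oc2=O)[nH]c2ccccc12)c1ccc(Cl)cc1F` — not yet measured

In a functional assay on MCF7 cells (Homo sapiens) for inhibition, read by MTT assay, with a stated time of 48 h (a lower number here means a stronger inhibitor, a higher number a weaker inhibitor), compound 1 gives > 192000 nM, which is a limit of the assay and not a number. In this assay compound 2 gives > 200000 nM, again a limit rather than a measured value. The step that the two limits leave unreadable from compound 1 to compound 2 therefore cannot be read. Within the data shown here, compound 2 thus stands at a limit, as does the one other value shown.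

Compound 3 differs from compound 2 by 4-chloro-2-fluorophenyl in place of 3-bromophenyl on a carbonyl carbon. Among the measured compounds shown here, the only measured step that bears on an exchange of the aryl group on the carbonyl carbon is a step that the two limits leave unreadable from compound 1 to compound 2, and with both values sitting at the limit of > 192000 nM in this assay, at which 1 of the 2 values shown sits, and the limit of > 200000 nM in this assay, at which 1 of the 2 values shown sits, there is no readable step to carry over. Compound 3 is therefore expected to return a limit as well, the step that the limit leaves unreadable from compound 2 to compound 3 being an estimate without readable support. The estimate for compound 3 is 250000 nM, in the range 80000 nM to 1000000 nM.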

Compound 3, half-maximal inhibitory concentration: > 200000 nM
Compound 3: a limit, no number (the forecaster's own chance of this, stated with the estimate: 85%); the middle value lies beyond the limit too.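

In this assay compound 3 gives > 200000 nM, a limit of the assay and not a number. Among these compounds, no step from compound 1 or compound 2 to compound 3 can be read. The compounds shown leave open how strongly any of the three inhibits, and whether the group on the carbonyl carbon matters.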